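From 4-bromobenzyl to 3-fluorobenzyl: expected step for compound 4

The source may report more compounds than this note shows. Statements on the series, on what has been measured and on what is new or still open speak of the compounds shown alone.

In a functional assay on HepG2 cells (Homo sapiens) for antiproliferative activity, read by MTT assay, with a stated time of 24 h (on this read-out lower numbers stand for stronger inhibition and higher numbers for weaker inhibition), compound 1 `C#CCOc1ccc2c(=O)c(-c3cc(OC)c(OC)cc3OC)coc2c1` gives 4950 nM and compound 3 `COc1cc(OC)c(-c2coc3cc(OCc4ccc(Br)cc4)ccc3c2=O)cc1OC` gives 1050 nM, the lower of these two numbers. Compound 2 `COc1cc(OC)c(-c2coc3cc(OCC(=O)c4cccc(C(F)(F)F)c4)ccc3c2=O)cc1OC` reads > 10000 nM, which is a limit of the assay. Compound 4 `COc1cc(OC)c(-c2coc3cc(OCc4cccc(F)c4)ccc3c2=O)cc1OC` carries 3-fluorophenyl in place of 4-bromophenyl on a saturated chain carbon bound to an oxygen on an aromatic ring. Two measured steps at this place bear on it: a 4.7-fold lower number from compound 1 to compound 3 (0.67 log units; beyond the scatter) and an at least 9.5-fold lower number from compound 2 to compound 3 (0.97 log units; beyond the scatter). Neither exchanges one halogen-bearing phenyl for another, so both give only loose guidance. A small step in this assay is therefore expected, within the scatter and leaning towards a higher number. The estimated step is a 1.7-fold higher number from compound 3 to compound 4 (0.23 log units; within the scatter). Compound 4 is expected at 1800 nM, with an estimated range of 600 nM to 5500 nM.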

Compound 4, half-maximal inhibitory concentration: 1230 nM
For compound 4 the middle estimate is 1.5-fold (0.17 log units) above the measured one, within the range that was stated.
By their numbers in this assay, from the lowest: compounds 3 and 4 (each within the scatter of the next); then compound 1. At a limit, above all of these: compound 2.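

In this assay, two different halogen-bearing phenyl groups read alike at this place, with a 1.2-fold higher number from compound 3 to compound 4 (0.07 log units; within the scatter) for 3-fluorophenyl in place of 4-bromophenyl. The gain over ethynyl is therefore not confined to 4-bromophenyl, as a 4.0-fold lower number from compound 1 to compound 4 (0.60 log units; beyond the scatter) shows for compound 4. Compound 2 is a limit of the assay, so an at least 8.1-fold lower number from compound 2 to compound 4 (0.91 log units; beyond the scatter) is only a floor on that gap.

Compound 2 carries both a carbonyl and a trifluoromethyl, and the compounds shown do not separate the two. From the compounds shown here alone, whether an amine, a carboxylic acid or a longer chain at this place would read alike remains open.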